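This account rests on a few compounds, and the source may have more. Where it says the series, first, only, none or still open, it means among the compounds named here.

- Compound 1 `CC/C(=C(/c1ccc(/C=C/C(=O)O)cc1)c1ccc2[nH]ncc2c1)c1ccccc1C#N`: 12 nM
- Compound 2 `CC/C(=C(/c1ccc(/C=C/C(=O)O)cc1)c1ccc2[nH]ncc2c1)c1ccccc1C`: 4 nM
- Compound 3 `CC/C(=C(/c1ccc(/C=C/C(=O)O)cc1)c1ccc2[nH]ncc2c1)c1ccc(C#N)cc1Cl`: 4 nM

In a functional assay on MCF7 cells (Homo sapiens) for cytotoxicity, read by CellTiter-Glo, with a stated time of 5 days (on this read-out lower numbers stand for stronger inhibition and higher numbers for weaker inhibition), compound 3 gives 4 nM. That is the same reading as compound 2, and the two share the lowest number of the three. The measurements show no change at the digits printed from compound 2 to compound 3 (within the scatter) and a 3.0-fold lower number from compound 1 to compound 3 (0.48 log units; beyond the scatter).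

Compound 4 `CC/C(=C(/c1ccc(/C=C/C(=O)O)cc1)c1ccc2[nH]ncc2c1)c1ccncc1Cl` alters one group of compound 3: 3-chloropyridin-4-yl in place of 2-chloro-4-cyanophenyl on a double-bonded chain carbon bound to a double-bonded chain carbon and a saturated chain carbon. In words, 3-chloropyridin-4-yl stands in place of 2-chloro-4-cyanophenyl on a double-bonded chain carbon bound to a double-bonded chain carbon and a saturated chain carbon.

The steps above all concern the group at this place, as does a 3.0-fold lower number from compound 1 to compound 2 (0.48 log units; beyond the scatter). Each of them is modest or lies within the scatter, so a large step in this assay is not expected. For the measured compounds named here, no measured compound has an aromatic ring with a hetero atom at this place, which leaves the direction uncertain. With compound 3 at the low end of the three numbers, a modest rise seems more likely than a further drop. The expected change is a 2.5-fold higher number from compound 3 to compound 4 (0.40 log units; beyond the scatter). For compound 4 the estimated value is 10 nM, with an expected range of 3 nM to 30 nM.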

Compound 4, half-maximal inhibitory concentration: 4 nM
Compound 4: the middle estimate sits 2.5-fold (0.40 log units) above what was measured; the measured number falls inside the stated range.
By their numbers in this assay, from the lowest: compounds 2, 3 and 4 (each within the scatter of the next); then compound 1.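

In this assay, the first aromatic ring with a hetero atom at this place, 3-chloropyridin-4-yl, gives no change at the digits printed from compound 3 to compound 4 (within the scatter) and no change at the digits printed from compound 2 to compound 4 (within the scatter), so neither a ring of carbon only nor the triple bond of 2-chloro-4-cyanophenyl is needed to hold this level. Against 2-cyanophenyl, the same exchange gives a 3.0-fold lower number from compound 1 to compound 4 (0.48 log units; beyond the scatter), which leaves compound 1 as the only one of the four set apart by more than the scatter. Nothing measured here bears on why these numbers fall as they do.

The compounds shown leave open whether 3-chloropyridin-4-yl would keep this level with an amine or a methoxy group in place of its chlorine. Also open, on these data alone, is whether the level seen in this assay carries over to any other read-out.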